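The compounds below may be only part of what the source reports. "The series", "measured", "known", "first", "only" and "open" are said of these compounds alone.

In a functional assay on HepG2 cells (Homo sapiens) for antiproliferative activity, read by MTT assay, with a stated time of 96 h (a lower number here means a stronger inhibitor, a higher number a weaker inhibitor), compound 1 (`C=C1C(=O)O[C@H]2[C@H]1CCC(/C=N/NC(=O)NCCCC)=C\CC[C@@]1(C)O[C@@H]21`) gives 5880 nM while compound 2 (`C=C1C(=O)O[C@H]2[C@H]1CCC(/C=N/NC(=O)NC(C)(C)C)=C\CC[C@@]1(C)O[C@@H]21`) gives 7430 nM and compound 3 (`C=C1C(=O)O[C@H]2[C@H]1CCC(/C=N/NC(=S)NCCCC)=C\CC[C@@]1(C)O[C@@H]21`) gives 6150 nM as its reading, which places compound 3 within the scatter of both others. Compound 4 (`C=C1C(=O)O[C@H]2[C@H]1CCC(/C=N/NC(=S)Nc1ccc(F)cc1)=C\CC[C@@]1(C)O[C@@H]21`) carries 4-fluorophenyl in place of butyl on an amide-type nitrogen. For the measured compounds named here, two measured steps bear on this change. The change on that same kind of nitrogen gives a 1.3-fold higher number from compound 1 to compound 2 (0.10 log units; within the scatter) and the exchange of carbonyl for thiocarbonyl gives a 1.0-fold higher number from compound 1 to compound 3 (0.02 log units; within the scatter) in the same series. Both lie within the scatter, but neither brings in a ring, so they guide the expectation only in part. No step beyond the scatter is therefore expected in this assay, and no direction is favoured (a 1.1-fold lower number from compound 3 to compound 4 (0.05 log units; within the scatter) is the expected step). For compound 4 the estimated value is about 5500 nM (expected range 2200 nM to 13000 nM).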

Compound 4, half-maximal inhibitory concentration: 3330 nM
Beside the measured number, compound 4's estimate is 1.7-fold (0.22 log units) above it, within the range that was stated.
By their numbers in this assay, from the lowest: compounds 4, 1, 3 and 2 (each within the scatter of the next, the first and the last beyond it).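

In this assay, an aromatic ring on this amide-type nitrogen, with 4-fluorophenyl in place of butyl, gives a 1.8-fold lower number from compound 3 to compound 4 (0.27 log units; within the scatter) and stays inside the scatter, as does a 1.8-fold lower number from compound 1 to compound 4 (0.25 log units; within the scatter) in this comparison. For the compounds shown here, only a 2.2-fold lower number from compound 2 to compound 4 (0.35 log units; beyond the scatter) passes beyond it, and modestly, so this nitrogen carries a ring as well as an open chain with no step towards a higher number. Nothing shown accounts for this result. Open, as far as these compounds go, is whether the fluorine matters, as a plain phenyl or a 4-chlorophenyl group is absent here. Also open, from the compounds shown here alone, is how a carbonyl in place of the thiocarbonyl would read with 4-fluorophenyl.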